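The compounds below may be only part of what the source reports. "The series", "measured", "known", "first", "only" and "open" are said of these compounds alone.

In a functional assay on NALM-6 cells (Homo sapiens) for cytotoxicity, read by luminescence and CellTiter-Glo, with a stated time of 3 days (on this read-out higher numbers stand for weaker inhibition and lower numbers for stronger inhibition), compound 1 (`N#Cc1ccc(NC(=O)c2cc(Cl)ccc2O)c(Cl)c1`) gives 730 nM and compound 2 (`O=C(Nc1cc(C(F)(F)F)cc(C(F)(F)F)c1)c1ccc(Br)cc1O`) gives 1200 nM as the numbers stand so far. Compound 3 (`N#Cc1ccc(NC(=O)c2ccc3cccnc3c2O)c(F)c1`) at 370 nM lies within the scatter of compound 1 and beyond the scatter of compound 2, whose number is higher. Compound 4 (`N#Cc1ccc(NC(=O)c2ccc3cccnc3c2O)cc1`) differs from compound 3 by hydrogen in place of fluoro on an aromatic carbon with hydrogen in place of fluoro on an aromatic carbon. Within the data shown here, no measured pair shows this change, so its size remains open. A small move in this assay toward a higher number is expected, none beyond the scatter. The estimated change is a 1.2-fold higher number from compound 3 to compound 4 (0.09 log units; within the scatter) and no more. For compound 4 the estimate is 450 nM with 180 nM to 1100 nM as the expected range.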

Compound 4, half-maximal inhibitory concentration: 130 nM
For compound 4 the middle estimate is 3.5-fold (0.54 log units) above the measured one; the measured number lies below the stated range.
By their numbers in this assay, from the lowest: compound 4; then compounds 3, 1 and 2 (each within the scatter of the next, the first and the last beyond it).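

In this assay the series shows a 2.8-fold lower number from compound 3 to compound 4 (0.45 log units; beyond the scatter) with hydrogen in place of fluoro, the first single-place step available. At this aromatic carbon, ortho to a large group and meta to a cyano group, fluoro is therefore not required for the activity, and hydrogen gives the stronger inhibition of the pair. No data at hand explain this shift.

Open, from the compounds shown here alone, is whether a methoxy group or an amine on this carbon would give a lower or higher number than hydrogen. Also open, going by these compounds, is whether the same change holds on the cores of compound 1 and compound 2.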